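Aryl exchange at the double-bonded chain carbon: compound 4

This account rests on a few compounds, and the source may have more. Where it says the series, first, only, none or still open, it means among the compounds named here.

Compound 1 `COc1cc(OC)cc(/C(=C\c2cn(C(C)=O)c3ccc(OCc4ccccc4)cc23)C(=O)O)c1` gives 30400 nM in a functional assay on KB cells (Homo sapiens) for cytotoxicity, read by MTT assay, with a stated time of 72 h; a higher number here means a weaker inhibitor, a lower number a stronger inhibitor. Compound 3 `O=C(O)/C(=C/c1c[nH]c2ccc(OCc3ccccc3)cc12)c1ccccc1` gives 55500 nM in this assay. For compound 2 `CC(=O)n1cc(/C=C(/C(=O)O)c2ccc(Cl)cc2)c2cc(OCc3ccccc3)ccc21` only a limit is known in this assay, > 100000 nM, so compound 2 stands at the limit of > 100000 nM in this assay, at which 1 of the 3 values shown sits, the high end of the numbers shown. Going by the values given here, the one measured step bearing on the change is an at least 3.2-fold higher number from compound 1 to compound 2 (0.51 log units; beyond the scatter), a loss on moving from a dimethoxyphenyl to the chlorophenyl. Compound 4 `COc1ccc(/C(=C\c2cn(C(C)=O)c3ccc(OCc4ccccc4)cc23)C(=O)O)cc1OC` carries 3,4-dimethoxyphenyl in place of 4-chlorophenyl on a double-bonded chain carbon bound to a carbonyl carbon and a double-bonded chain carbon. Since this reinstates a dimethoxyphenyl, though as 3,4-dimethoxyphenyl rather than the 3,5-dimethoxyphenyl of compound 1, a step toward lower numbers in this assay is expected, an at least 2.8-fold lower number from compound 2 to compound 4 (0.45 log units; beyond the scatter), roughly undoing the earlier loss. Compound 4 is therefore estimated at 35000 nM, within 12000 nM to 100000 nM.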

Compound 4, half-maximal inhibitory concentration: 96700 nM
For compound 4 the middle estimate is 2.8-fold (0.44 log units) below the measured one; the measured number falls inside the stated range.
By their numbers in this assay, from the lowest: compounds 1, 3 and 4 (each within the scatter of the next, the first and the last beyond it). At a limit, above all of these: compound 2.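

In this assay, the arrangement of the two methoxy groups matters at this position, with 3,4-dimethoxyphenyl in place of 3,5-dimethoxyphenyl giving a 3.2-fold higher number from compound 1 to compound 4 (0.50 log units; beyond the scatter). Having two methoxy groups on this aryl ring is therefore not enough to match compound 1, and exchanging 4-chlorophenyl for 3,4-dimethoxyphenyl gives an at least 1.0-fold lower number from compound 2 to compound 4 (0.01 log units; that floor lies within the scatter). From the compounds shown here alone, compound 2 has only a limit, > 100000 nM, so the true size of that step stays unknown.

Open, going by these compounds, is whether a single methoxy group, or an amine, on this aryl ring would shift the number. Also open, on these data alone, is how an amide in place of the carboxylic acid would read.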